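Longer alkylamino chains and cytotoxicity in HepG2 cells

The source may report more compounds than this note shows. Statements on the series, on what has been measured and on what is new or still open speak of the compounds shown alone.

Values in an ADME assay on HepG2 cells (Homo sapiens) for cytotoxicity, read by MTT assay, with a stated time of 72 h; on this read-out higher numbers stand for lower toxicity in this test and lower numbers for higher toxicity in this test:
- compound 1 `CCCNc1nc2cc(-c3ccc(C)cc3)sc2c(=O)[nH]1` gives > 62500 nM (a limit of the assay, not a number)
- compound 2 `CCCCNc1nc2cc(-c3ccc(C)cc3)sc2c(=O)[nH]1` gives 6000 nM
- compound 3 `CCCCCCNc1nc2cc(-c3ccc(C)cc3)sc2c(=O)[nH]1` gives 10600 nM

Compound 1 is known only as a limit: the limit of > 62500 nM in this assay, at which 1 of the 3 values shown sits. Compound 4 `CCCCCCCNc1nc2cc(-c3ccc(C)cc3)sc2c(=O)[nH]1` is unmeasured. It differs from compound 1 by butyl in place of hydrogen on a saturated chain carbon, three bonds along the chain from a nitrogen on an aromatic ring, which is butyl in place of hydrogen on a saturated chain carbon, or propyl to heptyl when cut further out.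

Two measured steps add to the same chain: an at least 10-fold lower number from compound 1 to compound 2 (1.01 log units; beyond the scatter) and an at least 5.8-fold lower number from compound 1 to compound 3 (0.77 log units; beyond the scatter). Both are beyond the scatter and both reach lower numbers, though each is bounded only from one side by the limit. A further extension, a 1.8-fold higher number from compound 2 to compound 3 (0.25 log units; within the scatter), stays within the scatter. A step of similar size in this assay is therefore expected, towards a lower number, with compound 4 landing near compound 2 and compound 3. The expected step runs an at least 6.9-fold lower number from compound 1 to compound 4 (0.84 log units; beyond the scatter). For compound 4 the estimated value is 9000 nM, with an expected range of 3500 nM to 25000 nM.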

Compound 4, half-maximal cytotoxic concentration: 6800 nM
Estimate against measurement, compound 4: 1.3-fold (0.12 log units) above; the measured number falls inside the stated range.
By their numbers in this assay, from the lowest: compounds 2, 4 and 3 (each within the scatter of the next). At a limit, above all of these: compound 1.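

In this assay the heptyl chain gives an at least 9.1-fold lower number from compound 1 to compound 4 (0.96 log units; beyond the scatter) and this step is bounded from one side only, as compound 1 stands at a limit. The longer chain adds no further change, since a 1.1-fold higher number from compound 2 to compound 4 (0.05 log units; within the scatter) and a 1.6-fold lower number from compound 3 to compound 4 (0.19 log units; within the scatter) both stay within the scatter, so compounds 2, 3 and 4 form a level run in this assay. The same methyl addition on the chain therefore counts for much on the shorter chain and for little on the longer one: the same change on two cores in this assay, an at least 10-fold lower number (1.01 log units; beyond the scatter) from compound 1 to compound 2 and a 1.6-fold lower number (0.19 log units; within the scatter) from compound 3 to compound 4, at least 6.6-fold (0.82 log units) apart, beyond the scatter of two such steps.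

Going by these compounds, whether the level run holds for an octyl or still longer chain remains open. Also open, on these data alone, is whether a branched chain, or a chain ending in an amine or a carboxylic acid, stays near compound 2 or returns towards compound 1.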